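Compound 4: An Expected Value from Its Neighbours

This account rests on a few compounds, and the source may have more. Where it says the series, first, only, none or still open, it means among the compounds named here.

Measured so far:
compound 1 `COc1cc(-n2cnc3ccc(-c4cccc(N)c4)cc32)cc(OC)c1OC` gives 640 nM in a functional assay on A549 cells (Homo sapiens) for antiproliferative activity, read by MTT assay, with a stated time of 72 h; a higher number here means a weaker inhibitor, a lower number a stronger inhibitor
compound 2 `COc1cc(-n2cnc3ccc(-c4ccc(C(F)(F)F)cc4)cc32)cc(OC)c1OC` gives 3390 nM
compound 3 `COc1cc(-n2cnc3ccc(-c4ccc(Cl)cc4Cl)cc32)cc(OC)c1OC` is reported only as a limit of the assay, > 10000 nM

Compound 2 holds the highest of the two numbers, and its nearest neighbour is compound 1, separated by a 5.3-fold higher number from compound 1 to compound 2 (0.72 log units; beyond the scatter). The unmeasured compound 4 `COc1cc(-n2cnc3ccc(-c4cccc(Cl)c4)cc32)cc(OC)c1OC` differs from compound 2 by 3-chlorophenyl in place of 4-(trifluoromethyl)phenyl on an aromatic carbon. Among the measured compounds shown here, two measured steps bear on this change: a single 3-aminophenyl substituent gave a lower number than 4-(trifluoromethyl)phenyl, as seen in a 5.3-fold higher number from compound 1 to compound 2 (0.72 log units; beyond the scatter), whereas a chlorinated 2,4-dichlorophenyl ring moved the number up, as seen in an at least 2.9-fold higher number from compound 2 to compound 3 (0.46 log units; beyond the scatter). A single 3-chlorophenyl is therefore expected to give a modest decrease in this assay, namely a 1.9-fold lower number from compound 2 to compound 4 (0.27 log units; within the scatter). Compound 4 is estimated at 1800 nM, within 500 nM to 7000 nM.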

Compound 4, half-maximal inhibitory concentration: 7050 nM
Estimate against measurement, compound 4: 3.9-fold (0.59 log units) below; the measured number lies above the stated range.
By their numbers in this assay, from the lowest: compound 1; then compound 2; then compound 4. At a limit, above all of these: compound 3.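

In this assay, a single chloro on this ring does not lower the number, as 3-chlorophenyl in place of 4-(trifluoromethyl)phenyl gives a 2.1-fold higher number from compound 2 to compound 4 (0.32 log units; beyond the scatter). With chloro in place of amino as the only difference, the pair shows an 11-fold higher number from compound 1 to compound 4 (1.04 log units; beyond the scatter), so the low number of compound 1 goes with its amino group and not with a single substituent as such. Compound 3 stands at a limit of the assay: the limit of > 10000 nM in this assay, at which 1 of the 4 values shown sits. Read against this limit, 3-chlorophenyl in place of 2,4-dichlorophenyl gives an at least 1.4-fold lower number from compound 3 to compound 4 (0.15 log units; that floor lies within the scatter) and leaves the true size of this step open.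

Going by these compounds, what remains open is whether amino would keep this advantage elsewhere on the ring, and how a hydroxyl or an acetamide would compare with it.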